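The source may report more compounds than this note shows. Statements on the series, on what has been measured and on what is new or still open speak of the compounds shown alone.

Measured compounds in an assay for binding affinity to Corticotropin releasing factor receptor (Rattus norvegicus); a higher number here means a weaker inhibitor, a lower number a stronger inhibitor:

compound 1, `CCc1nc2c(-c3ccc(Cl)cc3Cl)ccnc2n1[C@@H](CC)C1CC1`, 0.4 nM
compound 2, `CCCC(C)n1c(C(F)F)nc2c(-c3ccc(Cl)cc3Cl)ccnc21`, 15.8 nM
compound 3, `CCCC(C)n1c(CC)nc2c(-c3ccc(C(C)O)cc3Cl)ccnc21`, 5.1 nM

Compound 1 has the lowest inhibition constant of the three. The nearest of the others is compound 3, whose value is well beyond the scatter from that of compound 1; compound 2 sits further away still, also beyond the scatter. Compound 1 is therefore the reference point of the series as it stands.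

Compound 4, `CCc1nc2c(-c3ccc(Cl)cc3Cl)ccnc2n1C(CCOC)C1CC1`, has not yet been measured. It differs from compound 1 in one place: 1-cyclopropyl-3-methoxypropyl in place of 1-cyclopropylpropyl on an aromatic nitrogen. The shared core, the ethyl group and the dichlorophenyl ring are kept; the only alteration is the methoxy group on the third carbon of the chain that carries the cyclopropyl ring.

Among the compounds with values here, no measured pair in the set shows a step of this kind, so there is no direct precedent to lean on. The change is small in count and leaves the branching at the nitrogen intact. The expectation is that compound 4 stays close to compound 1, with a 2.5-fold higher number from compound 1 to compound 4 (0.40 log units; beyond the scatter) expected to be a modest loss at most, near the edge of the scatter. Compound 4 is estimated at 1 nM, within a range of 0.3 nM to 4 nM.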

Compound 4, inhibition constant: 1.5 nM
Compound 4: the middle estimate sits 1.5-fold (0.18 log units) below what was measured, within the range that was stated.
By their numbers in this assay, from the lowest: compound 1; then compound 4; then compound 3; then compound 2.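

In this assay, the substituent on the aromatic nitrogen accepts a longer chain carrying a hydrogen-bond acceptor at a modest cost: 1-cyclopropyl-3-methoxypropyl in place of 1-cyclopropylpropyl gives a 3.8-fold higher number from compound 1 to compound 4 (0.57 log units; beyond the scatter). Within the data shown here, this is the first step that can be read at a single place, and the cyclopropyl ring, the ethyl group and the dichlorophenyl ring are held constant across it, with compound 4 still at 1.5 nM. The data offer no measured property or other evidence that would account for the size of this loss.

As far as these compounds go, the step also carries a second difference, since 1-cyclopropylpropyl has one defined stereocentre in compound 1 and none is defined for 1-cyclopropyl-3-methoxypropyl in compound 4, so the share of the methoxy group in the loss stays open. Also open, from the compounds shown here alone, is how this position responds when a hydroxyl group, a dimethylamino group or a longer ether chain stands in place of the methoxy group.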